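Compound 2 to compound 3: swapping the amide substituent

The source may hold more compounds than are shown below. What is called first, only, known or untested is meant among the compounds shown, and "the series" means these compounds.

In a functional assay (QGY7701 cells, Homo sapiens) for inhibition, read by MTT assay, with a stated time of 48 h (on this read-out lower numbers stand for stronger inhibition and higher numbers for weaker inhibition), compound 1 (`COc1ccc2c(=O)c(/C=C/C(=O)Nc3cccc(Cl)c3)coc2c1`) gives > 100000 nM, which is a limit of the assay and not a number. For the measured compounds named here, compound 2 (`COc1cccc(NC(=O)/C=C/c2coc3cc(OC)ccc3c2=O)c1`) gives 39100 nM, the only true number so far. Compound 3 (`COc1ccc2c(=O)c(/C=C/C(=O)NCc3ccc(F)cc3)coc2c1`) is still unmeasured, and it carries 4-fluorobenzyl in place of 3-methoxyphenyl on an amide-type nitrogen. Going by the values given here, one measured step bears on this, and only indirectly: an at least 2.5-fold lower number from compound 1 to compound 2 (0.40 log units; beyond the scatter). That step exchanged a single group, whereas here the whole amide substituent changes. Compound 3 has no methoxy on this substituent, like compound 1, which supports expecting weaker inhibition by analogy with an at least 2.5-fold lower number from compound 1 to compound 2 (0.40 log units; beyond the scatter). The expected step is modest, with weak support: a 2.0-fold higher number from compound 2 to compound 3 (0.31 log units; beyond the scatter). The estimate for compound 3 is 80000 nM, with an expected range of 25000 nM to 150000 nM.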

Compound 3, half-maximal inhibitory concentration: 7960 nM
Compound 3: middle estimate off by 10-fold (1.00 log units), on the high side; the measured number lies below the stated range.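

In this assay, the amide-type nitrogen proves a productive place for change: 4-fluorobenzyl in place of 3-methoxyphenyl gives a 4.9-fold lower number from compound 2 to compound 3 (0.69 log units; beyond the scatter). Compound 3 carries no methoxy on this substituent, so methoxy is not required for a lower number here, and 4-fluorobenzyl in place of 3-chlorophenyl gives an at least 12-fold lower number from compound 1 to compound 3 (1.09 log units; beyond the scatter). Compound 1 stands at a limit of the assay, so this second step is a bound and not a measured size: the limit of > 100000 nM in this assay, at which 1 of the 3 values shown sits.

As far as these compounds go, whether the lower number follows the benzyl link or the fluorine stays open, as both enter together in compound 3. Also open, from the compounds shown here alone, is how a plain benzyl, a longer chain such as 2-phenylethyl, or a carboxylic acid on this substituent would read.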